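Aryl for Arylmethyl on a Ring Nitrogen

A few compounds are considered here, and "the series" means these few. Any claim that something is new, unique, unknown or untested is made for them only; others in the source may bear on it.

Measured compounds:
compound 1, `Nc1ccccc1NC(=O)c1ccc(CSC(=S)N2CCN(Cc3ccccn3)CC2)cc1`, 61.4%
compound 2, `Nc1ccccc1NC(=O)c1ccc(CSC(=S)N2CCN(C(c3ccccc3)c3ccccc3)CC2)cc1`, 13.8%
compound 3, `Nc1ccccc1NC(=O)c1ccc(CSC(=S)N2CCN(c3ccccc3)CC2)cc1`, 73.1%

In a functional assay on HeLa cells (Homo sapiens) for antiproliferative activity, read by CCK-8 assay, with a stated time of 72 h, tested at 8 uM (on this read-out higher numbers stand for a stronger effect at the one concentration tested and lower numbers for a weaker effect), compound 1 stands second of the three numbers. Compound 3 lies above it, by a number 11.7 percentage points higher from compound 1 to compound 3 (beyond the scatter). Compound 2 gives a far lower number than compound 1, and the two differ in more than one place, so only the two values themselves are known.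

Compound 4, `Nc1ccccc1NC(=O)c1ccc(CSC(=S)N2CCN(c3cccnc3)CC2)cc1`, differs from compound 1 by pyridin-3-yl in place of (pyridin-2-yl)methyl on an amine nitrogen in a ring. Among the measured compounds shown here, the one step that bears on this change is a number 11.7 percentage points higher from compound 1 to compound 3 (beyond the scatter), where an aromatic ring placed directly on the ring nitrogen gave a modest rise. A rise of similar size is therefore expected, a number 6.6 percentage points higher from compound 1 to compound 4 (within the scatter). Compound 4 is estimated at 68%, with a range from 52% to 82%.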

Compound 4, a percentage reported as inhibition, at one concentration (the size of the read-out at that concentration, not a potency): 72.5%
Beside the measured number, compound 4's estimate is 4.5 percentage points below it; the measured number falls inside the stated range.
By their numbers in this assay, from the lowest: compound 2; then compound 1; then compounds 4 and 3 (each within the scatter of the next).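

With pyridin-3-yl in place of (pyridin-2-yl)methyl on the amine nitrogen in the ring, the result is a number 11.1 percentage points higher from compound 1 to compound 4 (beyond the scatter) and shows that the rise seen with phenyl is not confined to that one aromatic ring. Pyridin-3-yl in place of phenyl gives a number 0.6 percentage points lower from compound 3 to compound 4 (within the scatter) and so the two groups cannot be told apart at this position. No evidence at hand accounts for either step.

On these data alone, it remains open how pyridin-2-yl, pyridin-4-yl or a saturated ring such as cyclohexyl would read on this nitrogen. As far as these compounds go, it is also open whether a plain benzyl group would match (pyridin-2-yl)methyl.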